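The compounds below may be only part of what the source reports. "The series", "measured", "known", "first", "only" and "open" are said of these compounds alone.

Measured so far:
- compound 1, `S=C(N/N=C/c1ccc2ccccc2n1)Nc1ccc(Br)cc1`: 56800 nM
- compound 2, `NC(=S)N/N=C/c1nc2ccccc2s1`: 5350 nM
- compound 3, `CN(C)C(=S)N/N=C/c1cc2cccnc2s1`: 48400 nM

In a functional assay on HeLa cells (Homo sapiens) for antiproliferative activity, read by sulforhodamine B assay, with a stated time of 72 h (on this read-out higher numbers stand for weaker inhibition and lower numbers for stronger inhibition), compound 1 gives 56800 nM, the highest number of the three. Compound 3 gives 48400 nM, a number so close to that of compound 1 that the two lie within the usual scatter; nothing about their order can be said. Compound 2 gives 5350 nM, a clearly lower number than compound 1, and that gap is beyond the scatter. For the measured compounds named here, no step between two measured compounds that differ in a single place is available, so the series gives no measured precedent for the change considered here.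

Compound 4, `S=C(NCc1ccccc1)N/N=C/c1ccc2ccccc2n1`, differs from compound 1 in one place: benzyl in place of 4-bromophenyl on an amide-type nitrogen. Going by the values given here, with no precedent in this assay, the step is expected to be small, in no definite direction, and not beyond the scatter: a 1.1-fold lower number from compound 1 to compound 4 (0.06 log units; within the scatter). Compound 4 is therefore estimated at 50000 nM in this assay, with a range from 15000 nM to 160000 nM.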

Compound 4, half-maximal inhibitory concentration: 62800 nM
For compound 4 the middle estimate is 1.3-fold (0.10 log units) below the measured one; the range from low to high includes it.
By their numbers in this assay, from the lowest: compound 2; then compounds 3, 1 and 4 (each within the scatter of the next).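

In this assay, for the compounds shown here, the first measured step at this position is a 1.1-fold higher number from compound 1 to compound 4 (0.04 log units; within the scatter) with benzyl in place of 4-bromophenyl on an amide-type nitrogen. It lies within the scatter, so the two groups cannot be told apart at this place on the core of compound 1. Moving from a ring carrying bromine to benzyl, with the heavy-atom count unchanged, therefore gives no measurable shift in this read-out, and neither group can be ranked above the other. Nothing available bears on why the two groups read alike.

Still open, from the compounds shown here alone, is whether any group on this nitrogen moves the number beyond the scatter, for example a morpholine ring, a carboxylic acid or a longer alkyl chain. Also open, going by these compounds, is whether benzyl and 4-bromophenyl stay equivalent on a different core.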